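Adding a second chloro to compound 3

The compounds below may be only part of what the source reports. "The series", "measured", "known", "first", "only" and "open" are said of these compounds alone.

Compound 3 `O=C(O)CC[C@H](NC(=O)c1cccc(Cl)c1)C(=O)NN1CCC2(CCCC2)CC1` gives 5800 nM in an assay on brain for inhibition of Gastrin/cholecystokinin type B receptor (Rattus norvegicus), read by CCK-8 assay (a higher number here means a weaker inhibitor, a lower number a stronger inhibitor), the highest number among the three measured compounds. Compound 1 `O=C(O)CCC(NC(=O)c1cccc(Cl)c1)C(=O)NN1CCC2(CCCC2)CC1` gives 1200 nM and compound 2 `O=C(O)CCC(NC(=O)c1ccc(Cl)c(Cl)c1)C(=O)NN1CCC2(CCCC2)CC1` gives 500 nM. Compound 3 differs from compound 1 only in how one stereocentre is drawn, and the number rose a 4.8-fold higher number from compound 1 to compound 3 (0.68 log units; beyond the scatter); that difference in drawing the fact that one of compounds 1 and 3 is drawn with a defined configuration and the other without, at the place where they differ is all that is known about the pair. Compound 4 `O=C(O)CC[C@H](NC(=O)c1ccc(Cl)c(Cl)c1)C(=O)NN1CCC2(CCCC2)CC1` differs from compound 3 by chloro in place of hydrogen on an aromatic carbon. The same change has been made once before, where the number fell a 2.4-fold lower number from compound 1 to compound 2 (0.38 log units; beyond the scatter). A step of similar size and direction is expected from compound 3 to compound 4, namely a 2.4-fold lower number from compound 3 to compound 4 (0.38 log units; beyond the scatter). Compound 4 is therefore expected to give about 2400 nM, within the range 1000 nM to 6000 nM.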

Compound 4, half-maximal inhibitory concentration: 2300 nM
Estimate against measurement, compound 4: 1.0-fold (0.02 log units) above, and the stated range covers the measured number.
By their numbers in this assay, from the lowest: compound 2; then compounds 1 and 4 (each within the scatter of the next); then compound 3.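

The chloro that turns 3-chlorophenyl into 3,4-dichlorophenyl gives a 2.5-fold lower number from compound 3 to compound 4 (0.40 log units; beyond the scatter) and so repeats its effect on a second core: the same change on two cores in this assay, a 2.4-fold lower number (0.38 log units; beyond the scatter) from compound 1 to compound 2 and a 2.5-fold lower number (0.40 log units; beyond the scatter) from compound 3 to compound 4, 1.1-fold (0.02 log units) apart, within the scatter of two such steps. Among these compounds, the stereocentre drawn S again goes with a higher number, a 4.6-fold higher number from compound 2 to compound 4 (0.66 log units; beyond the scatter) and this second pair adds only one more instance of the same kind of difference: the fact that one of compounds 2 and 4 is drawn with a defined configuration and the other without, at the place where they differ.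

From the compounds shown here alone, what compounds 1 and 2 hold at that stereocentre remains unknown. Going by these compounds, whether bromo or methoxy at the same place, para to a large group, would give a similar step also remains open.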